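Amino to Ethyl on a Cytotoxic Compound

The source may report more compounds than this note shows. Statements on the series, on what has been measured and on what is new or still open speak of the compounds shown alone.

compound 1 `Nc1ccc(-c2ccc(NC3=CC(=O)c4ncncc4C3=O)cc2)cc1`: 2500 nM
compound 2 `O=C1C(NCc2ccc(F)cc2)=CC(=O)c2ncncc21`: 1700 nM
compound 3 `COc1cccc(NC2=CC(=O)c3ncncc3C2=O)c1`: 1800 nM

All three compounds were tested in a functional assay on MIA PaCa-2 cells (Homo sapiens) for cytotoxicity, read by MTT assay, with a stated time of 72 h (on this read-out lower numbers stand for stronger inhibition and higher numbers for weaker inhibition), and share one core, with a different group attached to it in each. Compound 1 (2500 nM) lies within the usual scatter of repeated measurements of both compound 2 and compound 3. These figures therefore give no real ranking, even though the three numbers are not identical.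

Compound 4 `CCc1ccc(-c2ccc(NC3=CC(=O)c4ncncc4C3=O)cc2)cc1` has not been measured yet. It keeps the core of compound 1 but carries ethyl in place of amino on an aromatic carbon, turning 4-aminophenyl into 4-ethylphenyl, and the counted difference is ethyl in place of amino on an aromatic carbon for this single swap.

For the measured compounds named here, no pair of measured compounds differs in one place only, so nothing here shows directly what such a swap does. The expectation rests on the narrow spread alone: compound 2 (1700 nM) and compound 3 (1800 nM) carry other groups, yet both stay within the scatter of compound 1 (2500 nM). A small step is therefore expected, leaning slightly toward a lower number and not beyond the scatter. The expected size of the move is a 1.3-fold lower number from compound 1 to compound 4 (0.10 log units; within the scatter) in this assay by this estimate. For compound 4 the expected value is 2000 nM with a range from 700 nM to 5500 nM as the estimate.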

Compound 4, half-maximal inhibitory concentration: 2000 nM
Beside the measured number, compound 4's estimate shows no gap at the digits printed, within the range that was stated.
By their numbers in this assay, from the lowest: compounds 2, 3, 4 and 1 (each within the scatter of the next).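

For the compounds shown here, this is the first pair of compounds that differ in one place only, so it tests this swap directly: on an aromatic carbon para to a large group, amino, with 1 hydrogen-bond donor and 1 hydrogen-bond acceptor, gives way to ethyl, with 0 of each. In this assay the swap gives a 1.3-fold lower number from compound 1 to compound 4 (0.10 log units; within the scatter) and stays within the usual scatter, so this pair offers no sign that the read-out depends on which of these two groups sits at this position, and the amino group's donor and acceptor are not required for compound 4 to register in this assay. Going by these compounds alone, no separate measurement bears on this result, so the pair shows only that the two numbers cannot be told apart, and offers no explanation.

Still open, from the compounds shown here alone, is whether a group of a different kind at this position, such as a carboxylic acid, a dimethylamino group or a longer chain like hexyl, would move the number beyond the scatter. This single pair also leaves open whether the same swap would read alike on a compound with a different group on the shared core.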